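From Compound 1 to Compound 4: One Ring Swapped

This account rests on a few compounds, and the source may have more. Where it says the series, first, only, none or still open, it means among the compounds named here.

Of the compounds shown here, three have been tested in a functional assay on BGC-823 cells (Homo sapiens) for antiproliferative activity, read by MTT assay, tested at 1 uM; on this read-out higher numbers stand for a stronger effect at the one concentration tested and lower numbers for a weaker effect. Compound 1, `COc1cc(C2=NN(C(C)=O)C(c3cccc(F)c3)O2)cc(OC)c1OC`, gives 14.7%. Compound 2, `COc1cc(C(=O)N/N=C/c2cccc(C(F)(F)F)c2)cc(OC)c1OC`, gives 17.7%, a number within the scatter of compound 1 and the nearest to it. Compound 3, `COc1cc(C(=O)N/N=C/c2c(Cl)cccc2Cl)cc(OC)c1OC`, gives 0.9%, the furthest from compound 1 and lower by more than the scatter. On these numbers compound 1 stands second highest of three, and all three compounds act weakly at the one concentration tested.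

Compound 4, `COc1cc(C2=NN(C(C)=O)C(c3ccc(Cl)c([N+](=O)[O-])c3)O2)cc(OC)c1OC`, has not yet been measured in this assay. It differs from compound 1 in one place: 4-chloro-3-nitrophenyl in place of 3-fluorophenyl on a saturated ring carbon. Within the data shown here, no measured pair shows what such a swap does here, and the three numbers that exist give no trend to lean on. The step from compound 1 to compound 4 in this assay is therefore expected to be small, a number 3.3 percentage points higher from compound 1 to compound 4 (within the scatter), most likely not beyond the scatter, with no clear direction. Compound 4 is expected to give about 18%, within a range from 3% to 40%.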

Compound 4, a percentage reported as inhibition, at one concentration (the size of the read-out at that concentration, not a potency): -2.3%
The estimate for compound 4 lay 20.3 percentage points above the measured number; measured number below the stated range.
By their numbers in this assay, from the lowest: compounds 4 and 3 (each within the scatter of the next); then compounds 1 and 2 (each within the scatter of the next).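

Among these compounds, this is the first pair in the set that differs in one place, so it gives the first direct reading of the saturated ring carbon that lies next to the ring nitrogen and next to the ring oxygen. In this assay, placing 4-chloro-3-nitrophenyl there instead of 3-fluorophenyl gives a number 17 percentage points lower from compound 1 to compound 4 (beyond the scatter), so the aromatic group at this position can change the read-out by more than the usual scatter. Nothing available explains this drop.

The swap removes fluorine and brings in chlorine and a nitro group together, so the compounds shown cannot assign the drop to either new group alone. From the compounds shown here alone, how 4-chlorophenyl, 3-nitrophenyl, or a phenyl ring carrying an amine or a carboxylic acid would behave at this position remains open.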